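This account rests on a few compounds, and the source may have more. Where it says the series, first, only, none or still open, it means among the compounds named here.

In a functional assay on SK-BR-3 cells (Homo sapiens) for antiproliferative activity, read by MTT assay, with a stated time of 48 h (on this read-out lower numbers stand for stronger inhibition and higher numbers for weaker inhibition), two compounds sharing one core have been measured so far. Compound 1 (`COc1ccc(OC)c(CN2CCc3nc(N4CCN(c5ncccn5)CC4)ncc3C2)c1`) gives 10700 nM, and compound 2 (`COc1ccc(OC)c(C(=O)N2CCc3nc(N4CCN(c5ncccn5)CC4)ncc3C2)c1`) gives 23500 nM. Compound 2 therefore holds the higher number of the two, which makes it the weaker inhibitor, and its gap to compound 1 lies beyond the usual scatter.

Compound 3 (`O=C(c1ccc(F)cc1)N1CCc2nc(N3CCN(c4ncccn4)CC3)ncc2C1`) has yet to be measured. It departs from compound 2 in one place, with 4-fluorophenyl in place of 2,5-dimethoxyphenyl on a carbonyl carbon. No measured pair among these compounds varies this group, so the data offer no direct guide to the size of the step. Only a cautious expectation is possible. The expected step, a 1.6-fold lower number from compound 2 to compound 3 (0.19 log units; within the scatter), is small, an estimated slight move toward a lower number that is not expected to pass beyond the scatter. The estimate for compound 3 is 15000 nM, with the measurement expected to fall between 6000 nM and 40000 nM.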

Compound 3, half-maximal inhibitory concentration: 24500 nM
Compound 3: the middle estimate sits 1.6-fold (0.21 log units) below what was measured; measured number inside the range.
By their numbers in this assay, from the lowest: compound 1; then compounds 2 and 3 (each within the scatter of the next).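

In this assay, for the compounds shown here, the first change of the aryl group on this carbonyl carbon gives a 1.0-fold higher number from compound 2 to compound 3 (0.02 log units; within the scatter), so at this position the 2,5-dimethoxyphenyl group can give way to 4-fluorophenyl, which has fewer heavy atoms and no hydrogen-bond acceptors, with no change that can be read in this assay. The step that replaces 2,5-dimethoxybenzyl with (4-fluorophenyl)carbonyl on the amine nitrogen in a ring gives a 2.3-fold higher number from compound 1 to compound 3 (0.36 log units; beyond the scatter), so among these three compounds, the two with a carbonyl on that nitrogen both hold higher numbers than compound 1, and neither aryl group tested on the carbonyl closes that gap. Nothing shown here gives a measured reason why the two aryl groups read alike or why compound 1 stands apart.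

Going by these compounds, a 4-fluorobenzyl group on the same ring nitrogen would show whether the gap to compound 1 follows the carbonyl or the aryl substitution, and that comparison remains open. Also open, on these data alone, is whether anything other than a substituted phenyl ring on the carbonyl, such as a cyclohexyl ring, a longer alkyl chain or a phenyl ring carrying an amine or a carboxylic acid, would move the number beyond the scatter.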